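Benzyl in place of acetyl on compound 3

The source may hold more compounds than are shown below. What is called first, only, known or untested is meant among the compounds shown, and "the series" means these compounds.

Compound 3 `CC(=O)n1c(C(=O)N2CCC(C(=O)N(C)Cc3ccccc3)CC2)cc2ccccc21` has only a limit in an ADME assay on BE(2)-C cells (Homo sapiens) for cytotoxicity, read by MTT assay, with a stated time of 20 h (on this read-out lower numbers stand for higher toxicity in this test and higher numbers for lower toxicity in this test), > 50000 nM. Compound 1 `CN(Cc1ccccc1)C(=O)C1CCN(C(=O)c2cc3ccccc3n2Cc2ccc(C#N)cc2)CC1` also has only a limit, > 100000 nM. Compound 2 `COc1ccc(Cn2c(C(=O)N3CCC(C(=O)N(C)Cc4ccccc4)CC3)cc3ccccc32)cc1` gives a measured number, 99200 nM.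

The next change leads to compound 4 `CN(Cc1ccccc1)C(=O)C1CCN(C(=O)c2cc3ccccc3n2Cc2ccccc2)CC1`: benzyl in place of acetyl on an aromatic nitrogen. The closest measured comparisons are a step that the two limits leave unreadable from compound 1 to compound 3 and a step that the limit leaves unreadable from compound 2 to compound 3, and neither supplies a size. The substituted benzyl pair adds a number no higher from compound 1 to compound 2 (the limit leaves the size open).

With compound 2 at 99200 nM, compound 4 is expected to stay in the same high range of this assay. A limit is also possible for compound 4. The expected change is a step that the limit leaves unreadable from compound 3 to compound 4, with no step beyond the scatter anticipated. For compound 4 the estimate is 90000 nM, with an expected range of 40000 nM to 200000 nM.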

Compound 4, half-maximal cytotoxic concentration: 64800 nM
Compound 4: middle estimate off by 1.4-fold (0.14 log units), on the high side; the range from low to high includes it.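

In this assay, for the compounds shown here, the unsubstituted benzyl on the aromatic nitrogen gives the first comparisons at this place with a readable size: hydrogen in place of methoxy gives a 1.5-fold lower number from compound 2 to compound 4 (0.18 log units; within the scatter), and hydrogen in place of cyano gives an at least 1.5-fold lower number from compound 1 to compound 4 (0.18 log units; that floor lies within the scatter). Removing either substituent from the benzyl therefore shows no step beyond the scatter. Compound 3 has only a limit, and the steps to and from it cannot be read.

On these data alone, whether an amine or a carboxylic acid on the benzyl ring would give a step beyond the scatter stays open. The same holds for a longer chain in place of benzyl on the aromatic nitrogen.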